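From a Sulfur-Bearing Tail to a Nitrogen-Bearing Tail

The source may report more compounds than this note shows. Statements on the series, on what has been measured and on what is new or still open speak of the compounds shown alone.

Measured compounds:
compound 1, `Cc1c(C)c2c(c(C)c1O)CC[C@](C)(CC[S+](C)C)O2` — 2000 nM
compound 2, `Cc1c(C)c2c(c(C)c1O)CC[C@@](C)(CC[S+](C)C)O2` — 2000 nM

Of the compounds shown here, two have been measured. In a functional assay (brain) for inhibition, with Rattus norvegicus as the target (on this read-out higher numbers stand for weaker inhibition and lower numbers for stronger inhibition), compound 1 gives 2000 nM, and compound 2 gives 2000 nM. The two stand level on the digits shown, and the one measured step, no change at the digits printed from compound 1 to compound 2 (within the scatter), fits with the fact that compounds 1 and 2 differ only in the configuration as drawn: turning the drawn configuration of the ring carbon made no difference beyond the scatter.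

Compound 3, `Cc1c(C)c2c(c(C)c1O)CC[C@](C)(CC[N+](C)(C)C)O2`, has not yet been measured. Compared with compound 1 it carries a group of 4 heavy atoms (3 carbon, 1 nitrogen; no ring) in place of a group of 3 heavy atoms (2 carbon, 1 sulfur; no ring), on a saturated chain carbon, two bonds along the chain from a saturated ring carbon. For the measured compounds named here, no measured step touches this part of the molecule, since the only step known concerns configuration alone, so it offers no guide to the size of the change. The charged group is kept, and a modest shift in either direction seems as likely as none. Compound 3 is therefore expected to sit near compound 1, with an estimated step of no change at the digits printed from compound 1 to compound 3 (within the scatter). The estimate for compound 3 in this assay is 2000 nM, in the range 500 nM to 8000 nM.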

Compound 3, half-maximal inhibitory concentration: 2200 nM
Compound 3: the middle estimate sits 1.1-fold (0.04 log units) below what was measured, and the stated range covers the measured number.
By their numbers in this assay, from the lowest: compounds 1, 2 and 3 (each within the scatter of the next).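

In this assay, for the compounds shown here, exchanging the sulfur-bearing group for the nitrogen-bearing one gives a 1.1-fold higher number from compound 1 to compound 3 (0.04 log units; within the scatter), the first step here in which the atoms themselves differ rather than only the drawn configuration. So, on a saturated chain carbon, two bonds along the chain from a saturated ring carbon, one group with net charge +1 can stand in for another, even with the larger count of heavy atoms, without a change beyond the scatter. The information available offers no explanation for why the two groups read alike.

From the compounds shown here alone, it remains open whether a tail with no net charge, such as a hydroxyl group or a carboxylic acid, or a longer chain would read the same way. Going by these compounds, it is also open whether the nitrogen-bearing tail, like the sulfur-bearing one, is indifferent to the drawn configuration at the ring carbon.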